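Plasma protein binding in a benzoxazolone/benzisoxazole acid series

A few compounds are considered here, and "the series" means these few. Any claim that something is new, unique, unknown or untested is made for them only; others in the source may bear on it.

Measured compounds:
compound 1 `C[C@@H](Oc1cc2onc(CCC(=O)O)c2cc1Cl)c1ccc(Cl)cn1`: 99.8%
compound 2 `O=C(O)CCn1c(=O)oc2cc(OCc3ccccn3)c(Cl)cc21`: 92.6%
compound 3 `C[C@@H](Oc1cc2c(cc1Cl)N(CCC(=O)O)C(=O)CO2)c1ccccn1`: 92.5%

In an ADME assay on a cell-free system (plasma, Homo sapiens) for protein binding, compound 1 gives 99.8%, compound 2 gives 92.6% and compound 3 gives 92.5%. Compound 2 and compound 3 sit within the scatter of one another, so no order between them is claimed; compound 1 stands apart, with a far lower unbound fraction that lies beyond the scatter. All three carry the propanoic acid chain and a chlorine on the aromatic ring; compound 1 also carries a second chlorine on its pyridine.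

Compound 4 `CCOc1cc2oc(=O)n(CCC(=O)O)c2cc1Cl` has not yet been measured in this assay. Relative to compound 2 the change is methyl in place of pyridin-2-yl on a saturated chain carbon bound to an oxygen on an aromatic ring. Among the measured compounds shown here, no measured pair shows this kind of change, so there is no step to rest on. The step from compound 2 to compound 4 is expected to be small and, if anything, toward a slightly lower bound percentage: a 1.4-fold higher unbound fraction from compound 2 to compound 4 (0.13 log units; within the scatter), within the scatter. Compound 4 is estimated at 90% in this assay, with a range of 80% to 96%.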

Compound 4, plasma protein binding: 95.8%
The estimate for compound 4 lay 2.4-fold (0.38 log units) (unbound fraction) above the measured number; the range from low to high includes it.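

Among the compounds shown here, this is the first pair that differs in one place: in this assay, methyl in place of pyridin-2-yl on a saturated chain carbon bound to an oxygen on an aromatic ring gives a 1.8-fold lower unbound fraction from compound 2 to compound 4 (0.25 log units; within the scatter) and stays within the scatter. The pyridine ring can therefore leave this position, as (pyridin-2-yl)methoxy gives way to ethoxy, without a shift that can be told from repeat variation in this pair. Nothing at hand accounts for this result.

Still open, going by these compounds, is how an amine, or a longer chain in place of ethoxy, would read at this position in this assay. Also open, on these data alone, is whether the same change would read alike on the core of compound 1 or of compound 3.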